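From 3-nitrophenyl to 4-methoxyphenyl on the shared core

The compounds below may be only part of what the source reports. "The series", "measured", "known", "first", "only" and "open" are said of these compounds alone.

In a functional assay on A-431 cells (Homo sapiens) for antiproliferative activity, read by CCK-8 assay, with a stated time of 72 h (on this read-out higher numbers stand for weaker inhibition and lower numbers for stronger inhibition), compound 1 `Cc1cc(Nc2cc(N3CCN(C)CC3)nc(Nc3ccc([N+](=O)[O-])cc3)n2)n[nH]1` gives 150 nM and compound 2 `Cc1cc(Nc2cc(N3CCN(C)CC3)nc(Nc3cccc([N+](=O)[O-])c3)n2)n[nH]1` gives 166 nM on the same core. Within the data shown here, only one step has been measured so far, a 1.1-fold higher number from compound 1 to compound 2 (0.04 log units; within the scatter), with 3-nitrophenyl in place of 4-nitrophenyl on a nitrogen on an aromatic ring. Compound 2 therefore stands within the scatter of compound 1, and these two numbers are the only reference points.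

Compound 3 `COc1ccc(Nc2nc(Nc3cc(C)[nH]n3)cc(N3CCN(C)CC3)n2)cc1` carries 4-methoxyphenyl in place of 3-nitrophenyl on a nitrogen on an aromatic ring, and the counted difference reads (4-methoxyphenyl in place of 3-nitrophenyl on a nitrogen on an aromatic ring). Among the measured compounds shown here, no measured compound lacks a nitrophenyl group, so the data contain no direct measure of this exchange. For the measured compounds named here, the only guide is the small size of the measured step from compound 1 to compound 2. On that thin basis, no step beyond the scatter is expected in this assay, and the estimated step is a 1.1-fold higher number from compound 2 to compound 3 (0.04 log units; within the scatter) with a wide margin on either side. For compound 3 the expected value is 180 nM with an estimated range from 60 nM to 540 nM in this series.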

Compound 3, half-maximal inhibitory concentration: 385 nM
Beside the measured number, compound 3's estimate is 2.1-fold (0.33 log units) below it; low and high end bracket the measured number.
By their numbers in this assay, from the lowest: compounds 1 and 2 (each within the scatter of the next); then compound 3.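

In this assay, among these compounds, the earlier pair, with a 1.1-fold higher number from compound 1 to compound 2 (0.04 log units; within the scatter) as its only step, showed no response to where the nitro group sits on the ring, whereas this first exchange of the nitro group itself shows that the position does respond to what the ring carries. Methoxy in place of nitro on an aromatic carbon gives a 2.6-fold higher number from compound 1 to compound 3 (0.41 log units; beyond the scatter) as the comparison of 4-nitrophenyl with 4-methoxyphenyl, and 4-methoxyphenyl in place of 3-nitrophenyl gives a 2.3-fold higher number from compound 2 to compound 3 (0.37 log units; beyond the scatter) as well, so compound 3 stands apart from both nitrophenyl compounds. Both steps are modest, so the change shifts the number without abolishing activity, and nothing at hand accounts for the shift.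

Going by these compounds, whether the higher number follows the loss of nitro or the arrival of methoxy stays open, and a plain phenyl, a 4-aminophenyl or a 4-carboxyphenyl group on this nitrogen would help to separate the two. Also open, on these data alone, is whether 3-methoxyphenyl would behave like 4-methoxyphenyl, as the two nitrophenyl groups do in this assay.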